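This account rests on a few compounds, and the source may have more. Where it says the series, first, only, none or still open, it means among the compounds named here.

Compound 1 `CCN1C(=O)N(CC)C2C1N=C(SC)N2/N=C/C=C/c1ccccc1` is the starting point. In a functional assay on MCF7 cells (Homo sapiens) for inhibition, read by MTT assay, with a stated time of 72 h (on this read-out higher numbers stand for weaker inhibition and lower numbers for stronger inhibition), compound 1 gives 46600 nM. Compound 2 `CCN1C(=O)N(CC)C2C1N=C(SC)N2/N=C/C=C/c1ccccc1[N+](=O)[O-]` differs from it by one change, (nitro in place of hydrogen on an aromatic carbon), and in this assay compound 2 gives 66700 nM; the step of a 1.4-fold higher number from compound 1 to compound 2 (0.16 log units; within the scatter) is small, so the two compounds cannot be told apart on this read-out. Compound 3 `CCN1C(=O)N(CC)C2C1NC(=O)N2/N=C/C=C/c1ccccc1` carries a different core; the difference between the core of compound 1 and the core of compound 3 is not broken down here. In this assay compound 3 gives 83200 nM, which sits close to the other two values. Compound 4 `CCN1C(=O)N(CC)C2C1NC(=O)N2/N=C/C=C/c1ccccc1[N+](=O)[O-]` is not yet measured. It stands to compound 3 as compound 2 stands to compound 1: the change is nitro in place of hydrogen on an aromatic carbon, at the same place as before, so it is the same change on the other core. Because the earlier step of a 1.4-fold higher number from compound 1 to compound 2 (0.16 log units; within the scatter) stayed within the scatter, a step of about a 1.2-fold higher number from compound 3 to compound 4 (0.08 log units; within the scatter) is expected from compound 3 to compound 4. Compound 4 is therefore estimated at 100000 nM, most likely between 50000 nM and 250000 nM.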

Compound 4, half-maximal inhibitory concentration: 88000 nM
For compound 4 the middle estimate is 1.1-fold (0.06 log units) above the measured one; the range from low to high includes it.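

In this assay the change from phenyl to 2-nitrophenyl gives a 1.1-fold higher number from compound 3 to compound 4 (0.02 log units; within the scatter) on the second core, so here too the two compounds cannot be told apart. Set side by side, the steps on the two cores agree: the same change on two cores in this assay, a 1.4-fold higher number (0.16 log units; within the scatter) from compound 1 to compound 2 and a 1.1-fold higher number (0.02 log units; within the scatter) from compound 3 to compound 4, 1.4-fold (0.13 log units) apart, within the scatter of two such steps. Within the data shown here, this shows only that the change leaves no readable mark on either of these two cores in this one assay; it does not show that the change has no effect at all, since a small real effect could be hidden in the scatter, and it says nothing about a third core or about any other assay.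

The compounds shown leave open whether a different group on that aromatic carbon, such as an amine or a carboxylic acid, would produce a step large enough to read. They also leave open whether replacing the ethyl groups on the core with a longer chain would shift the numbers.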